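This account rests on a few compounds, and the source may have more. Where it says the series, first, only, none or still open, it means among the compounds named here.

In a functional assay on 1321-N1 cells for agonist activity at Free fatty acid receptor 1 (Homo sapiens), read by calcium flux, with a stated time of 0.4 s (a lower number here means a smaller maximal response, a higher number a larger maximal response), three compounds with a shared core have been measured, differing only in the group attached to a triple-bonded carbon. Compound 1 `O=C(O)CCc1ccc(C#CC2CCCC2)cc1` carries a cyclopentyl group and gives 94%. Compound 2 `O=C(O)CCc1ccc(C#CC2CC2)cc1` carries a cyclopropyl group and gives 128%. Compound 3 `O=C(O)CCc1ccc(C#CC2CCCCC2)cc1` carries a cyclohexyl group and gives 98%. Compound 3 thus stands second highest of the three; its nearest neighbour is compound 1, within the scatter, and its furthest is compound 2, beyond it.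

Compound 4 `C=C(C)C#Cc1ccc(CCC(=O)O)cc1` differs from compound 3 in one place: 1-methylethenyl in place of cyclohexyl on a triple-bonded carbon.

Among the compounds with values here, the steps that bear on this are those that swap the group on the triple-bonded carbon. a number 34 percentage points higher from compound 1 to compound 2 (beyond the scatter) and a number 30 percentage points lower from compound 2 to compound 3 (beyond the scatter) show that the three-membered ring gave the largest maximal response, while a number 4 percentage points higher from compound 1 to compound 3 (within the scatter) shows no difference between the two larger rings. Whether a group of three carbons without a ring behaves like cyclopropyl is not shown by any measured pair. Compound 4 is therefore expected to give a modest rise, a number 17 percentage points higher from compound 3 to compound 4 (beyond the scatter), with an estimated 115% in this assay, in a range from 95% to 140%.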

Compound 4, largest response reached (reported as efficacy), in percent of the reference or control that the assay uses: 108%
Beside the measured number, compound 4's estimate is 7 percentage points above it, within the range that was stated.
By their numbers in this assay, from the lowest: compounds 1, 3 and 4 (each within the scatter of the next, the first and the last beyond it); then compound 2.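

In this assay a ring on the triple-bonded carbon turns out not to be needed to keep the response seen with the larger rings: putting 1-methylethenyl in place of cyclohexyl gives a number 10 percentage points higher from compound 3 to compound 4 (within the scatter) and so no real change. Set against cyclopentyl, the same group does stand apart, with a number 14 percentage points higher from compound 1 to compound 4 (beyond the scatter) even though cyclopentyl and cyclohexyl could not be told apart, so the differences among these three compounds sit close to what this read-out can separate. The group without a ring does not reach the cyclopropyl result, with a number 20 percentage points lower from compound 2 to compound 4 (beyond the scatter) leaving compound 2 the highest of the four, so the high response of cyclopropyl is not matched by 1-methylethenyl.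

An isopropyl group on the triple-bonded carbon would be the direct comparison for judging whether the double bond of 1-methylethenyl matters, and a cyclobutyl group would show how the response runs from cyclopropyl to cyclopentyl. Nothing given here accounts for any of these differences.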